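A few compounds are considered here, and "the series" means these few. Any claim that something is new, unique, unknown or untested is made for them only; others in the source may bear on it.

Of the compounds shown here, two built on a shared core have been measured so far. Compound 1 `COc1cc(Cn2cc(COc3cccc(/C=C4/C(=O)Nc5ccccc54)c3)nn2)cc(OC)c1` in a functional assay on DU-145 cells (Homo sapiens) for inhibition, read by MTT assay, with a stated time of 48 h (on this read-out higher numbers stand for weaker inhibition and lower numbers for stronger inhibition), gives 25600 nM. Compound 2 `O=C1Nc2ccc(Cl)cc2/C1=C/c1cccc(OCc2cn(Cc3ccccc3)nn2)c1` in this assay gives 24200 nM. The two numbers sit close together, and the gap between them falls within the usual scatter of repeated measurements, so neither compound can be called the stronger inhibitor; both slow the growth of these cells only at high concentration.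

Compound 3 `CC(=O)c1ccc2c(c1)/C(=C/c1cccc(OCc3cn(Cc4ccccc4)nn3)c1)C(=O)N2` has not yet been measured. It differs from compound 2 in a single place: acetyl in place of chloro on an aromatic carbon. Going by the values given here, no pair of measured compounds shows what this exchange does on its own, and the one measured pair differs in several places at once, so it offers no guide. With nothing pointing in either direction, the exchange is expected to leave the number essentially where it is, as a step of a 1.2-fold higher number from compound 2 to compound 3 (0.09 log units; within the scatter). Compound 3 is therefore expected to give roughly 30000 nM in this assay, with a likely range from 12000 nM to 80000 nM.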

Compound 3, half-maximal inhibitory concentration: > 50000 nM
Compound 3: a limit, no number (the forecaster's own chance of this, stated with the estimate: 20%); middle value at least 1.6-fold (0.22 log units) away from the limit.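

Unlike the earlier compounds, this pair isolates a single change, on an aromatic carbon of a six-membered aromatic ring of carbon only. In this assay, acetyl in place of chloro gives an at least 2.0-fold higher number from compound 2 to compound 3 (0.31 log units; beyond the scatter), so the group at this place can shift the result, and here the shift is toward weaker inhibition of these cells. The result for compound 3 is a limit and not a number, so the step has a lower bound but no upper one: the limit of > 50000 nM in this assay, at which 1 of the 3 values shown sits.

One pair cannot separate the possible contributions of what enters with acetyl, namely its larger count of heavy atoms, its double bond outside the aromatic rings and its hydrogen-bond acceptor, from the loss of the chlorine. Going by these compounds alone, it also remains open how other groups at the same place would read in this assay, such as a methyl, a methoxy, an amine or a carboxylic acid, and whether the same exchange would have a similar effect on a compound with a different substituted benzyl group, such as the one in compound 1.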